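The compounds below may be only part of what the source reports. "The series", "measured", "known", "first", "only" and "open" are said of these compounds alone.

Compound 1 `COc1ccc(-c2nc(-c3ccc(OC)cc3)c(CC(=O)O)s2)cc1` — in an in vitro functional assay on HEK285-7 cells for antagonist activity at prostaglandin D2 receptor 2 (Homo sapiens), read by BRET and beta-arrestin recruitment (a higher number here means a larger maximal response, a lower number a smaller maximal response), compound 1 reaches > 70%, which is a limit of the assay rather than a number.
Compound 2 `COc1ccc(-c2nc(-c3ccc(Br)cc3)c(CC(=O)O)s2)cc1` — in this assay compound 2 reaches > 70%, again a limit of the assay.

Within the data shown here, compound 2 thus stands at the limit of this assay, and the one other value shown sits at the same limit (the limit of > 70% in this assay, at which 2 of the 2 values shown sit). Among the measured compounds shown here, the only measured step, a step that the two limits leave unreadable from compound 1 to compound 2, is therefore not readable in size, because both of its ends are limits.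

Compound 3 `COc1ccc(-c2nc(-c3ccccc3)c(CC(=O)O)s2)cc1` has not yet been measured in this assay. Its difference from compound 2 is hydrogen in place of bromo on an aromatic carbon. The step from compound 1 to compound 2 is the only one that bears on this change, and it shows no readable size, so no direction can be taken from it; what the data offer is simply that both measured compounds sit at the limit. The step that the limit leaves unreadable from compound 2 to compound 3 is accordingly expected to be none beyond the usual scatter. Compound 3 is estimated to reach 80%, with a range from 62% to 100%.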

Compound 3, largest response reached (reported as efficacy), in percent of the reference or control that the assay uses: > 70%
Compound 3 ended at the assay's limit; the forecaster's own chance of this, stated with the estimate: 75%; the middle value lies beyond the limit too.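

In this assay compound 3 gives > 70%, which is a limit of the assay and not a number. The steps among compound 1, compound 2 and compound 3 therefore cannot be read in size, because all three values sit at one limit: the limit of > 70% in this assay, at which 3 of the 3 values shown sit. The compounds shown leave open whether methoxy, bromo or hydrogen on that aromatic carbon changes the maximal response at all.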